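The source may report more compounds than this note shows. Statements on the series, on what has been measured and on what is new or still open speak of the compounds shown alone.

The measured compounds:
Compound 1 `O=C(CCCCCCc1ccccc1Cl)c1ncc(-c2ccccn2)o1`: in an assay for inhibition of Fatty-acid amide hydrolase 1 (Rattus norvegicus) (a higher number here means a weaker inhibitor, a lower number a stronger inhibitor), compound 1 gives 1.9 nM.
Compound 2 `CC(C)(C)OC(=O)Nc1ccc(CCCCCCC(=O)c2ncc(-c3ccccn3)o2)cc1`: in this assay compound 2 gives 5.6 nM.

Compound 1 has the lower of the two numbers in this assay; compound 2 sits at a higher number, and the gap between them lies beyond the usual scatter. Compound 3 `CSc1ccccc1CCCCCCC(=O)c1ncc(-c2ccccn2)o1` has not yet been measured. It differs from compound 1 in one place: methylsulfanyl in place of chloro on an aromatic carbon. Within the data shown here, no pair of measured compounds shares this change, so the size of the step has no measured precedent. The chain and the shared core are left untouched, and the account expects only a small step in this assay, probably none beyond the scatter, with a slight lean towards a higher number. The step from compound 1 to compound 3 is estimated as a 1.6-fold higher number from compound 1 to compound 3 (0.20 log units; within the scatter). For compound 3 the expected value is 3 nM, within a range from 1 nM to 9 nM.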

Compound 3, inhibition constant: 3.3 nM
Beside the measured number, compound 3's estimate is 1.1-fold (0.04 log units) below it; measured number inside the range.
By their numbers in this assay, from the lowest: compounds 1, 3 and 2 (each within the scatter of the next, the first and the last beyond it).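

Swapping chloro for methylsulfanyl on this aromatic carbon, ortho to a large group, gives a 1.7-fold higher number from compound 1 to compound 3 (0.24 log units; within the scatter) in this assay, so here two heavy atoms, one carbon and one sulfur, stand in place of a single chlorine without a step beyond the scatter. Among these compounds, this is the first step that can be read in one place, since the two earlier compounds differ in more than one. No measurement shown gives a reason for the size of this step.

On these data alone, whether an amine, a carboxylic acid, a methoxy group or plain hydrogen on this aromatic carbon would also stay within the scatter of compound 1 remains open. So does whether methylsulfanyl would give a similar step on another carbon of the ring or with a shorter chain.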